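Methoxy on the phenyl ring: expected cytotoxicity of compound 3

The source may hold more compounds than are shown below. What is called first, only, known or untested is meant among the compounds shown, and "the series" means these compounds.

Compound 1 `NC(=O)c1sc2nc(-c3ccccc3)cc(C(F)(F)F)c2c1N` and compound 2 `Nc1c(C(=O)NCc2cccs2)sc2nc(-c3ccccc3)cc(C(F)(F)F)c12` have been measured so far.

In an ADME assay on Huh-7 cells (Homo sapiens) for cytotoxicity, read by MTT assay, with a stated time of 72 h (on this read-out higher numbers stand for lower toxicity in this test and lower numbers for higher toxicity in this test), compound 1 gives > 20000 nM, which is a limit of the assay. Compound 2 gives > 20000 nM, also a limit. The step that the two limits leave unreadable from compound 1 to compound 2 therefore cannot be read, and compound 1 itself stands only at a limit (the limit of > 20000 nM in this assay, at which 2 of the 2 values shown sit). Compound 3 `COc1ccccc1-c1cc(C(F)(F)F)c2c(N)c(C(N)=O)sc2n1` differs from compound 1 by methoxy in place of hydrogen on an aromatic carbon. Among the compounds with values here, no measured step bears on this change, and the one step known is unreadable. Compound 3 is expected to remain at or beyond the limit, with a step that the limit leaves unreadable from compound 1 to compound 3 estimated near zero. The estimate for compound 3 is 30000 nM, ranging from 15000 nM to 80000 nM.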

Compound 3, half-maximal cytotoxic concentration: > 20000 nM
Compound 3 was reported as a limit; the forecaster's own chance of this, stated with the estimate: 85%; the middle value does not contradict the limit.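

No step can be read from compound 1 to compound 3, as both stand at a limit: the limit of > 20000 nM in this assay, at which 3 of the 3 values shown sit. On these data alone, how compound 1, compound 2 and compound 3 compare in this assay stays open, as does whether either substitution changes the read-out.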